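A few compounds are considered here, and "the series" means these few. Any claim that something is new, unique, unknown or untested is made for them only; others in the source may bear on it.

Working notes on the series. Going by the values given here, compound 1 `CC(C)(C)CCC1(NCc2ccc3ccccc3c2)C(=O)C(C2=NS(=O)(=O)c3cc(NS(C)(=O)=O)ccc3N2)=C(O)c2ccccc21` is the lower of the two numbers so far: in an ADME assay on the whole organism (plasma, strain Sprague-Dawley) for pharmacokinetics, with Rattus norvegicus as the target, at a dose of 5 mg/kg by the oral route (a higher number here means more compound in the circulation at the dose given, a lower number less compound in the circulation), compound 1 gives 1020 ng.h/mL, while compound 2 `Cc1cccc(C)c1CN[C@]1(CCC(C)(C)C)C(=O)C(C2=NS(=O)(=O)c3cc(NS(C)(=O)=O)ccc3N2)=C(O)c2ccccc21` gives 4210 ng.h/mL in this assay, a gap that lies beyond the usual scatter. Compound 3 `Cc1cccc(CNC2(CCC(C)(C)C)C(=O)C(C3=NS(=O)(=O)c4cc(NS(C)(=O)=O)ccc4N3)=C(O)c3ccccc32)n1` is not yet measured; it differs from compound 1 by 6-methylpyridin-2-yl in place of naphthalen-2-yl on a saturated chain carbon bound to an amine nitrogen. Among the compounds with values here, no measured pair shows this change, so the step from compound 1 to compound 3 is expected to be small, a 1.1-fold higher number from compound 1 to compound 3 (0.03 log units; within the scatter), with neither direction favoured beyond the scatter. For compound 3 the estimate in this assay is 1100 ng.h/mL, within a range of 350 ng.h/mL to 3500 ng.h/mL.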

Compound 3, area under the concentration-time curve: 1340 ng.h/mL
The estimate for compound 3 lay 1.2-fold (0.09 log units) below the measured number; the range from low to high includes it.
By their numbers in this assay, from the lowest: compounds 1 and 3 (each within the scatter of the next); then compound 2.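

On a saturated chain carbon bound to an amine nitrogen, 6-methylpyridin-2-yl in place of naphthalen-2-yl gives a 1.3-fold higher number from compound 1 to compound 3 (0.12 log units; within the scatter) in this assay. At this position, a single aromatic ring with 1 hetero atom therefore reads the same within the scatter as the 2 aromatic rings of carbon only. No measurement bearing on a cause for this result is available. The compounds shown leave open how pyridin-2-yl without the methyl would read here in this assay. They also leave open how a cyclohexyl group or a group carrying a carboxylic acid would read at this position.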